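A few compounds are considered here, and "the series" means these few. Any claim that something is new, unique, unknown or untested is made for them only; others in the source may bear on it.

In an ADME assay on L6 cells (Rattus norvegicus) for cytotoxicity, read by fluorescence and resazurin assay, with a stated time of 72 h (a lower number here means that less compound is tolerated, a higher number that more compound is tolerated), compound 1 `Cc1ccc(-c2c[nH]cc2C(c2ccc(Cl)cc2Cl)n2ccnc2)cc1` gives 18400 nM. Going by the values given here, the only other measured compound, compound 2 `Clc1ccc(C(c2c[nH]cc2-c2ccc(Cl)cc2-c2ccccc2)n2ccnc2)c(Cl)c1`, gives 14300 nM. Among the compounds with values here, these two values lie within the usual scatter of each other, so neither compound stands apart on the numbers so far. Compound 3 `CSc1ccc(-c2c[nH]cc2C(c2ccc(Cl)cc2Cl)n2ccnc2)cc1` keeps the core of compound 1 but has methylsulfanyl in place of methyl on an aromatic carbon. Within the data shown here, no measured pair of compounds shows this change, so the data give no direct size for it in this assay. Only a small move toward a lower number is expected, probably not beyond the scatter, and the estimate stays close to compound 1 at 18400 nM. The expected change is a 1.2-fold lower number from compound 1 to compound 3 (0.09 log units; within the scatter). Compound 3 is expected at 15000 nM, with an estimated range from 7000 nM to 30000 nM.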

Compound 3, half-maximal cytotoxic concentration: 7220 nM
Compound 3: the middle estimate sits 2.1-fold (0.32 log units) above what was measured; the measured number falls inside the stated range.
By their numbers in this assay, from the lowest: compounds 3, 2 and 1 (each within the scatter of the next, the first and the last beyond it).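

In this assay, replacing methyl with methylsulfanyl, on an aromatic carbon para to a large group, gives a 2.5-fold lower number from compound 1 to compound 3 (0.41 log units; beyond the scatter). Going by these compounds alone, this is the first step that isolates a single change, and it shows that this swap alone, which turns 4-methylphenyl into 4-(methylsulfanyl)phenyl, moves the number beyond the scatter, toward less compound being tolerated. No available measurement accounts for the step.

This single pair cannot show whether the direction and size of the step are particular to methylsulfanyl or would recur with other groups at this place. From the compounds shown here alone, it remains open how methoxy, a chlorine atom, methylsulfonyl or a longer chain such as ethylsulfanyl would compare with methyl and methylsulfanyl here.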